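The source may hold more compounds than are shown below. What is called first, only, known or untested is meant among the compounds shown, and "the series" means these compounds.

Measured compounds in a functional assay for agonist activity at G protein-coupled receptor 88 (Homo sapiens), read by HTRF and cAMP accumulation; on this read-out higher numbers stand for an effect only at larger amounts of compound and lower numbers for an effect already at smaller amounts:
Compound 1 `CC(C)CCCN(C(=O)[C@@H]1C[C@H]1c1ccccc1)c1ccc(-c2ccccc2)cc1` gives > 100 nM, which is a limit of the assay and not a number.
Compound 2 `CC[C@H](C)[C@H](N)CN(C(=O)[C@@H]1C[C@H]1c1cc(F)cc(F)c1)c1ccc(-c2ccccc2)cc1` gives 960 nM.
Compound 3 `CC(C)C[C@H](N)CN(C(=O)[C@@H]1C[C@H]1c1ccccc1)c1ccc(-c2cccnc2)cc1` gives 10000 nM.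

Of the two numbers that are not limits, compound 3 stands highest in this assay; its nearest neighbour is compound 2, whose value lies a full order below it, beyond the usual scatter. The third value shown, that of compound 1, is only a limit of > 100 nM in this assay, at which 1 of the 3 values shown sits, and sets no number to compare against.

Compound 4 `Cc1ccc(-c2ccc(N(C[C@@H](N)CC(C)C)C(=O)[C@@H]3C[C@H]3c3ccccc3)cc2)cc1` is not yet measured. It differs from compound 3 in one place: 4-methylphenyl in place of pyridin-3-yl on an aromatic carbon. Within the data shown here, no pair of measured compounds differs in exactly this way, so the size of the step cannot be read from the data. Compound 2, which carries a phenyl rather than a pyridin-3-yl, gives 960 nM, but it also differs from compound 3 elsewhere, so this shows only what its own value is.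

Compound 4 is therefore expected to give about 2500 nM in this assay, with a plausible range from 500 nM to 10000 nM. That estimate means a step of a 4.0-fold lower number from compound 3 to compound 4 (0.60 log units; beyond the scatter), a moderate move toward lower numbers that is not assured to exceed the scatter.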

Compound 4, half-maximal effective concentration: 360 nM
For compound 4 the middle estimate is 6.9-fold (0.84 log units) above the measured one; the whole stated range lies above it.
By their numbers in this assay, from the lowest: compound 4; then compound 2; then compound 3.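

In this assay, the place para to a large group on the six-membered aromatic ring of carbon only proves highly responsive to change: replacing pyridin-3-yl with 4-methylphenyl gives a 28-fold lower number from compound 3 to compound 4 (1.44 log units; beyond the scatter). This is the first step among the compounds shown that differs in one place, so it is the first direct reading of this position, and its size is large and beyond the scatter. The exchange removes the ring nitrogen and adds a methyl group, leaving a ring of carbon only with no hydrogen-bond acceptors, but nothing measured here accounts for the size of the step.

No pair among the compounds shown separates the loss of the ring nitrogen from the gain of the methyl group, so the share of each in this step remains open. Also open, as far as these compounds go, is how a 4-chlorophenyl, a 4-methoxyphenyl or a pyridin-4-yl would behave at this position, and whether a step of this size would carry over to a compound with a different amine side chain or a fluorinated phenyl on the cyclopropane.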